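Boc-Pyrrolidinyl Replacement on a Purine Aminopyrimidine Core

This account rests on a few compounds, and the source may have more. Where it says the series, first, only, none or still open, it means among the compounds named here.

Measured compounds:
compound 1 `CN1CCN(c2ccc(Nc3ncc4nc(Nc5ccc(F)cc5)n([C@H]5CCCNC5)c4n3)cc2)CC1`, 38 nM
compound 2 `CN1CCN(c2ccc(Nc3ncc4nc(Nc5ccc(F)cc5)n([C@@H]5CCCNC5)c4n3)cc2)CC1`, 120 nM

In a functional assay on HCC827 cells (Homo sapiens) for antiproliferative activity, read by MTT assay, with a stated time of 72 h (a lower number here means a stronger inhibitor, a higher number a weaker inhibitor), compound 2 gives 120 nM, the highest of the two numbers; its nearest neighbour is compound 1, which gives 38 nM. Within the data shown here, the only measured step is a 3.2-fold higher number from compound 1 to compound 2 (0.50 log units; beyond the scatter), a modest change that rests on the fact that compounds 1 and 2 differ only in the configuration as drawn alone. Compound 3 `CN1CCN(c2ccc(Nc3ncc4nc(Nc5ccc(F)cc5)n([C@@H]5CCN(C(=O)OC(C)(C)C)C5)c4n3)cc2)CC1` carries a different group: 1-(tert-butoxycarbonyl)pyrrolidin-3-yl in place of piperidin-3-yl on an aromatic nitrogen. This change removes the hydrogen-bond donor of the six-membered ring and brings in a tert-butoxycarbonyl group and a five-membered ring in its place. Among the measured compounds shown here, no measured step touches this kind of exchange, so the single configurational step offers no direct guide to its size. An account in the third person must therefore hold its estimate loosely. The author expects compound 3 to be a weaker inhibitor than compound 2, with a step of a 3.3-fold higher number from compound 2 to compound 3 (0.52 log units; beyond the scatter) in this assay, and estimates 400 nM, within a range from 100 nM to 2000 nM.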

Compound 3, half-maximal inhibitory concentration: 27 nM
Compound 3: the middle estimate sits 15-fold (1.17 log units) above what was measured, and the stated range ends above it.
By their numbers in this assay, from the lowest: compounds 3 and 1 (each within the scatter of the next); then compound 2.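

In this assay, the position on the aromatic nitrogen accepts 1-(tert-butoxycarbonyl)pyrrolidin-3-yl, with its 12 heavy atoms and 0 hydrogen-bond donors, in place of piperidin-3-yl, with its 6 heavy atoms and 1 hydrogen-bond donor, and the exchange gives a 4.4-fold lower number from compound 2 to compound 3 (0.65 log units; beyond the scatter) and a 1.4-fold lower number from compound 1 to compound 3 (0.15 log units; within the scatter) in the same assay. The earlier pair showed only that the configuration of piperidin-3-yl matters here, whereas compound 3 shows that among these compounds a hydrogen-bond donor in this group is not needed to reach the level of compound 1. The reading of the exchange also depends on the reference, since it lies beyond the scatter against one configuration of piperidin-3-yl and within it against the other.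

The exchange alters the ring size and adds the tert-butoxycarbonyl group at once, so the two remain unseparated, and pyrrolidin-3-yl with a free ring amine or piperidin-3-yl carrying tert-butoxycarbonyl on its ring nitrogen would be the groups to tell them apart. Nothing available here accounts for the size of either step.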